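Fluoro for Chloro on the Benzylsulfanyl Arm

A few compounds are considered here, and "the series" means these few. Any claim that something is new, unique, unknown or untested is made for them only; others in the source may bear on it.

Of the compounds shown here, three have been tested in a functional assay on the whole organism (artery, strain albino) with Rattus norvegicus as the target, with a stated time of 300 min, at a dose of 10 mg/kg by the oral route; on this read-out lower numbers stand for less inhibition and higher numbers for more inhibition at the one dose given (going by the name of the read-out). Compound 1 `CC1=C(C(=O)Nc2ccc(F)cc2)C(c2ccc([N+](=O)[O-])cc2)N=C(SCc2ccc(Cl)cc2)N1` gives 37.9%, and compound 2 `CC1=C(C(=O)Nc2ccc(F)cc2)C(c2ccc([N+](=O)[O-])cc2)N=C(SCc2ccc(F)cc2)N1` gives 30.3%; the step of a number 7.6 percentage points lower from compound 1 to compound 2 (within the scatter) follows the change (fluoro in place of chloro on an aromatic carbon). Compound 3 `CC1=C(C(=O)Nc2ccc(Br)cc2)C(c2ccc(Cl)cc2Cl)N=C(SCc2ccc(Cl)cc2)N1` gives 38.5%; how its core differs from that of compound 1 is not broken down here. Compound 4 `CC1=C(C(=O)Nc2ccc(Br)cc2)C(c2ccc(Cl)cc2Cl)N=C(SCc2ccc(F)cc2)N1` has not yet been measured in this assay. It arises from compound 3 by fluoro in place of chloro on an aromatic carbon, the same change as that from compound 1 to compound 2, made at the same place. The earlier change gave a number 7.6 percentage points lower from compound 1 to compound 2 (within the scatter). A step of similar size is expected here, a number 7.5 percentage points lower from compound 3 to compound 4 (within the scatter). Compound 4 is therefore estimated at 31%, with an expected range from 20% to 42%.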

Compound 4, a percentage reported as inhibition, in the whole organism at one dose (the size of the read-out at that dose, not a potency): 38.5%
Compound 4: middle estimate off by 7.5 percentage points, on the low side; low and high end bracket the measured number.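

In this assay, the change from 4-chlorobenzyl to 4-fluorobenzyl on the core of compound 3 shows no change at the digits printed from compound 3 to compound 4 (within the scatter), and set beside the same change on the core of compound 1, the two steps do not differ: the same change on two cores in this assay, a number 7.6 percentage points lower (within the scatter) from compound 1 to compound 2 and no change at the digits printed (within the scatter) from compound 3 to compound 4, 7.6 percentage points apart, within the scatter of two such steps. Nothing here therefore separates how the change behaves on one core from how it behaves on the other. Both steps lie within the scatter, however, so the pair shows neither a real effect of the change on either core nor a fixed size that carries from core to core.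

From the compounds shown here alone, whether an amine or a carboxylic acid in place of the halogen, or a longer chain in place of the 4-chlorobenzyl, would shift the read-out beyond the scatter remains open. Also open, going by these compounds, is whether the two halogens would separate at any other dose.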